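Fluoro for Chloro: the Step from Compound 2 to Compound 3

A few compounds are considered here, and "the series" means these few. Any claim that something is new, unique, unknown or untested is made for them only; others in the source may bear on it.

For the measured compounds named here, compound 2 `COc1ccc(CCc2nnc3n2N=C(c2ccc(Cl)cc2)CS3)cc1` stands highest of the two numbers so far available in a functional assay on the whole organism (strain BALB/c) with Mus musculus as the target, in the writhing test, with a stated time of 1 h, at a dose of 200 mg/kg by the oral route (a higher number here means a stronger effect of the compound at the dose given, a lower number a weaker effect), where compound 2 gives 62.4%. Its nearest neighbour is compound 1 `COc1ccc(Cc2n[nH]c(=S)n2N)cc1`, which in this assay gives 46.7%, a result lower by more than the usual scatter of such measurements. Compound 3 `COc1ccc(CCc2nnc3n2N=C(c2ccc(F)cc2)CS3)cc1` has not yet been tested; it differs from compound 2 in a single place: fluoro in place of chloro on an aromatic carbon. Going by the values given here, no measured pair in this set shows the same change, so its effect in this assay is not known from these data. On the figures available, the step from compound 2 to compound 3 is expected to be small, a number 6.4 percentage points lower from compound 2 to compound 3 (within the scatter), most likely within the scatter and if anything slightly downward. Compound 3 is therefore estimated to give about 56% in this assay, with a range from 42% to 70%.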

Compound 3, a percentage reported as inhibition, in the whole organism at one dose (the size of the read-out at that dose, not a potency): 37%
For compound 3 the middle estimate is 19 percentage points above the measured one, outside the stated range (below it).
By their numbers in this assay, from the lowest: compounds 3 and 1 (each within the scatter of the next); then compound 2.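

In this assay, for the compounds shown here, the group on this ring proves not to be interchangeable: the change from 4-chlorophenyl to 4-fluorophenyl gives a clear loss (a number 25.4 percentage points lower from compound 2 to compound 3 (beyond the scatter)), something the earlier compounds, which held no such pair, could not show. The place on an aromatic carbon, para to a large group, therefore matters for the read-out at this dose, although only one heavy atom is exchanged and no ring, hydrogen-bond donor, hydrogen-bond acceptor or net charge enters or leaves. Nothing available bears on the reason for this loss.

The compounds shown leave open how bromo, methyl, a nitrile or an amine at the same place would compare with chloro and fluoro. They also leave open whether this step would keep its size at other doses.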